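A few compounds are considered here, and "the series" means these few. Any claim that something is new, unique, unknown or untested is made for them only; others in the source may bear on it.

Measured in a functional assay on KB cells (Homo sapiens) for inhibition, with a stated time of 72 h; a lower number here means a stronger inhibitor, a higher number a weaker inhibitor:
- compound 1 `COc1cc(C(=O)c2cccc3cc[nH]c23)cc(OC)c1OC` gives 310 nM
- compound 2 `COc1cc(C(=O)c2ccc3c(ccn3C)c2)cc(OC)c1OC` gives 13.6 nM

A lower number marks the stronger inhibitor, so compound 2 at 13.6 nM stands lowest of the two. Compound 1 at 310 nM lies higher, and that gap is beyond the usual scatter of repeat measurements. Among the compounds with values here, with only two measured compounds, this gives a starting point but no trend.

The next compound is compound 3 `COc1cc(C(=O)c2ccc3c(ccn3CCC(=O)O)c2)cc(OC)c1OC`, which keeps the framework of compound 2 and changes one place. The change is carboxymethyl in place of hydrogen on a saturated chain carbon bound to an aromatic nitrogen. Put another way, a methyl becomes a 2-carboxyethyl.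

Within the data shown here, no measured pair shows this change, so the expectation below is a judgement and not a reading from a matching step. Because compound 2 at 13.6 nM is the lower of the two values, there is more room for the number to rise than to fall. A clear rise beyond the scatter is expected, meaning a weaker inhibitor, and the estimated size is a 22-fold higher number from compound 2 to compound 3 (1.34 log units; beyond the scatter). The estimate for compound 3 is 300 nM, with an expected range from 40 nM to 2500 nM.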

Compound 3, half-maximal inhibitory concentration: > 10000 nM
Compound 3 ended at the assay's limit (the forecaster's own chance of this, stated with the estimate: 10%); middle value at least 33-fold (1.52 log units) away from the limit.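

Compound 2 and compound 3 differ only in the group carried on the aromatic nitrogen, and this single change, methyl to 2-carboxyethyl, gives an at least 730-fold higher number from compound 2 to compound 3 (2.86 log units; beyond the scatter), so what sits at this position matters greatly in this assay. Compound 3 sits at a limit of the assay and not at a number: the limit of > 10000 nM in this assay, at which 1 of the 3 values shown sits. Before this pair, no two measured compounds differed in one place, so this is the first direct reading of a change on that nitrogen, and it shows that a chain ending in a carboxylic acid leaves compound 3 a far weaker inhibitor than compound 2.

Going by these compounds, this one step cannot separate the effect of the longer chain from that of the acid at its end, so it stays open whether a plain propyl chain, a methyl ester of the acid or a chain ending in an amine would stay close to compound 2 or fall away like compound 3. On these data alone, it is also open how a bare hydrogen on that nitrogen would compare with the methyl of compound 2.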